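The source may report more compounds than this note shows. Statements on the series, on what has been measured and on what is new or still open speak of the compounds shown alone.

Measured compounds:

Compound 1 `CN(C)CCn1cnnc1-c1cc(Oc2ccc(NC(=O)N/N=C/c3cccc(O)c3)cc2F)ccn1` gives 1370 nM in a functional assay on MKN-45 cells (Homo sapiens) for cytotoxicity, read by MTT assay, with a stated time of 72 h; on this read-out higher numbers stand for weaker inhibition and lower numbers for stronger inhibition.
Compound 2 `CN(C)CCn1cnnc1-c1cc(Oc2ccc(NC(=O)N/N=C/c3c[nH]c4ccccc34)cc2F)ccn1` gives 790 nM in this assay.
Compound 3 `COc1cc(/C=N/NC(=O)Nc2ccc(Oc3ccnc(-c4nncn4CCN(C)C)c3)c(F)c2)cc(OC)c1OC` gives 2900 nM in this assay.

All three compounds share one core and differ only in the aromatic group on a carbon with a double bond to nitrogen. On the numbers shown, compound 3 stands at the highest value, that is, the weakest inhibition of the three. Its gaps to the other two are both beyond the scatter: there was a 2.1-fold higher number from compound 1 to compound 3 (0.33 log units; beyond the scatter) and a 3.7-fold higher number from compound 2 to compound 3 (0.56 log units; beyond the scatter). Compound 1 and compound 2 sit close together, with a 1.7-fold lower number from compound 1 to compound 2 (0.24 log units; within the scatter).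

Compound 4 `CN(C)CCn1cnnc1-c1cc(Oc2ccc(NC(=O)N/N=C/c3ccccc3)cc2F)ccn1` has not yet been measured. It differs from compound 3 in one place: phenyl in place of 3,4,5-trimethoxyphenyl on a carbon with a double bond to nitrogen. Of the steps seen so far, the two that start or end at compound 3 bear on this change, since both replace the 3,4,5-trimethoxyphenyl with a different aromatic group and both lower the number. Phenyl is the plain six-membered aromatic ring, closest in kind to the 3-hydroxyphenyl of compound 1, so a step back toward the value of compound 1 is expected, of roughly the size a 1.9-fold lower number from compound 3 to compound 4 (0.29 log units; within the scatter). Compound 4 is therefore estimated at 1500 nM, with a range of 600 nM to 3500 nM.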

Compound 4, half-maximal inhibitory concentration: 2730 nM
The estimate for compound 4 lay 1.8-fold (0.26 log units) below the measured number, and the stated range covers the measured number.
By their numbers in this assay, from the lowest: compounds 2, 1, 4 and 3 (each within the scatter of the next, the first and the last beyond it).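

Going from 3,4,5-trimethoxyphenyl to phenyl on this carbon with a double bond to nitrogen keeps the number in this assay within the scatter (a 1.1-fold lower number from compound 3 to compound 4 (0.03 log units; within the scatter)), so losing the methoxy groups alone does not reproduce the gaps that separate compound 3 from the two earlier compounds. Hydrogen in place of hydroxy on an aromatic carbon also stays within the scatter (a 2.0-fold higher number from compound 1 to compound 4 (0.30 log units; within the scatter)), which leaves the phenyl of compound 4 indistinguishable from both of its neighbours, even though those two neighbours are themselves separated (a 2.1-fold higher number from compound 1 to compound 3 (0.33 log units; beyond the scatter)). Among the groups shown, only 1H-indol-3-yl stands clearly apart from phenyl (a 3.5-fold higher number from compound 2 to compound 4 (0.54 log units; beyond the scatter)), with the lower number on the side of the indole.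

Nothing measured here gives a reason for these steps. Still open, from the compounds shown here alone, is whether the position responds to anything other than the indole, for example a phenyl carrying an amine or a carboxylic acid, or a second two-ring group such as naphthyl on the same carbon.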